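Removing One Chlorine from a Dichloropurine Benzyl Compound

The source may hold more compounds than are shown below. What is called first, only, known or untested is meant among the compounds shown, and "the series" means these compounds.

Measured compounds:
compound 1, `ClCc1ccc(Cn2cnc3c(Cl)ncnc32)cc1`: > 100000 nM
compound 2, `ClCc1ccccc1Cn1cnc2c(Cl)nc(Cl)nc21`: 470 nM

For the measured compounds named here, in a functional assay on CCRF-CEM cells (Homo sapiens) for cytotoxicity, read by sulforhodamine B assay, with a stated time of 48 h (a lower number here means that less compound is tolerated, a higher number that more compound is tolerated), compound 2 gives 470 nM, the only real number in hand. Compound 1 gives > 100000 nM, which is a limit of the assay rather than a number. One of the two values therefore sits at the limit of > 100000 nM in this assay, at which 1 of the 2 values shown sits. Compound 3 `ClCc1ccccc1Cn1cnc2c(Cl)ncnc21` has not been measured yet. It arises from compound 2 by hydrogen in place of chloro on an aromatic carbon, the carbon sitting between two ring nitrogen atoms. Going by the values given here, no step between two measured compounds is available, so the size of this change has not been settled by data here. Compound 3 is expected to be tolerated more readily than compound 2, by roughly a 13-fold higher number from compound 2 to compound 3 (1.11 log units; beyond the scatter). The estimate for compound 3 is 6000 nM, most likely somewhere from 1000 nM to 60000 nM, and a limit instead of a number is a real possibility.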

Compound 3, concentration lethal to 50% of the cells: 8120 nM
Compound 3: the middle estimate sits 1.4-fold (0.13 log units) below what was measured; measured number inside the range.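

In this assay, the chloro group on the aromatic carbon between two ring nitrogen atoms proves to count for a great deal: putting hydrogen in its place gives a 17-fold higher number from compound 2 to compound 3 (1.24 log units; beyond the scatter). For the compounds shown here, this is the first measured step between two compounds that differ in one place, so the size of this change now rests on data. Compound 3 also gives a real number and not a limit, which lets the step be read in full, and only one compound remains at the edge of the assay's range: the limit of > 100000 nM in this assay, at which 1 of the 3 values shown sits.

From the compounds shown here alone, only chloro and hydrogen appear at this position, and what an amine, a methyl group or a fluorine there would do remains open. The data also give no reason for the step, and they show this change only once, with the rest of the molecule held fixed.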